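The source may report more compounds than this note shows. Statements on the series, on what has been measured and on what is new or still open speak of the compounds shown alone.

Among the compounds with values here, in an ADME assay on HEL cells (Homo sapiens) for cytotoxicity, with a stated time of 3 days (a higher number here means that more compound is tolerated, a lower number that less compound is tolerated), compound 3, `Cc1cn([C@@H]2O[C@H](CO[Si](C)(C)C(C)(C)C)[C@@]3(OS(=O)(=O)C=C3NC(=O)Nc3ccccc3)[C@H]2O[Si](C)(C)C(C)(C)C)c(=O)n(C)c1=O`, stands alone among the three measured compounds as the only one with a firm number, giving 1400 nM. Compound 1, `Cc1cn([C@@H]2O[C@H](CO[Si](C)(C)C(C)(C)C)[C@@]3(OS(=O)(=O)C=C3NC(=O)NC(=O)c3ccccc3)[C@H]2O[Si](C)(C)C(C)(C)C)c(=O)n(C)c1=O`, reaches only a limit of the assay, >= 80000 nM. Compound 2, `Cc1cn([C@@H]2O[C@H](CO[Si](C)(C)C(C)(C)C(C)C)[C@@]3(OS(=O)(=O)C=C3NC(=O)NC(=O)c3ccccc3)[C@H]2O[Si](C)(C)C(C)(C)C(C)C)c(=O)n(C)c1=O`, likewise reaches only a limit, >= 100000 nM. Compound 4, `Cc1cn([C@@H]2O[C@H](CO[Si](C)(C)C(C)(C)C)[C@@]3(OS(=O)(=O)C=C3NC(=O)N(C(=O)Nc3ccccc3)c3ccccc3)[C@H]2O[Si](C)(C)C(C)(C)C)c(=O)n(C)c1=O`, differs from compound 3 in a single place: phenylcarbamoyl in place of hydrogen on an amide-type nitrogen.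

Within the data shown here, one measured step bears on this change: an at least 57-fold lower number from compound 1 to compound 3 (1.75 log units; beyond the scatter). That step shows that taking a carbonyl-bearing group off the urea nitrogen left much less compound tolerated. Compound 4 puts a carbonyl-bearing group, the phenylcarbamoyl, back onto an amide-type nitrogen, so a move back toward the untoxic end is expected, though how far cannot be told from one step. Compound 4 is therefore expected to give 12000 nM, within a range from 2500 nM to 80000 nM, because compound 1 sits at the limit of >= 80000 nM in this assay, at which 1 of the 3 values shown sits. The expected step is an 8.6-fold higher number from compound 3 to compound 4 (0.93 log units; beyond the scatter).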

Compound 4, minimum cytotoxic concentration: 46000 nM
Compound 4: middle estimate off by 3.8-fold (0.58 log units), on the low side; the range from low to high includes it.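

In this assay adding the phenylcarbamoyl group gives a 33-fold higher number from compound 3 to compound 4 (1.52 log units; beyond the scatter) between two firm numbers, so the size of this change is known. A phenylcarbamoyl group on this amide-type nitrogen, whose other neighbours are an aromatic carbon and a carbonyl carbon, therefore leaves far more compound tolerated than hydrogen does in this pair. The earlier comparison could not give a size in this way, as compound 1 has a limit and not a number: the limit of >= 80000 nM in this assay, at which 1 of the 4 values shown sits.

The phenylcarbamoyl group brings a carbonyl, an extra nitrogen and a phenyl ring together, so the compounds shown do not separate their parts. Going by these compounds, how an acetyl group, a methyl group or a chain ending in a carboxylic acid on this nitrogen would behave in this assay also remains open.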